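Aryl ether variation and tolerated concentration in the series

The source may hold more compounds than are shown below. What is called first, only, known or untested is meant among the compounds shown, and "the series" means these compounds.

Compound 1 `Cc1cc(Br)cc(C)c1Oc1cc(Nc2ccc(C#N)cc2)ncc1[N+](=O)[O-]` and compound 2 `N#Cc1ccc(Nc2cc(Oc3c(Cl)cccc3Cl)c([N+](=O)[O-])cn2)cc1` share one core and differ only in the aryl ether. Among the measured compounds shown here, in an ADME assay on MT4 cells (Homo sapiens) for inhibition, read by MTT assay, with a stated time of 5 days (a higher number here means that more compound is tolerated, a lower number that less compound is tolerated), compound 2 gives 27700 nM, the higher of the two numbers available, while compound 1 gives 12300 nM; the single step of a 2.3-fold higher number from compound 1 to compound 2 (0.35 log units; beyond the scatter) is the only one bearing on this position. Compound 3 `N#Cc1ccc(Nc2cc(Oc3c(Br)cc(Br)cc3Br)c([N+](=O)[O-])cn2)cc1` carries 2,4,6-tribromophenyl in place of 2,6-dichlorophenyl on an oxygen on an aromatic ring. One step of that size gives little basis for a direction, so no step beyond the scatter is expected. Compound 3 is expected near 20000 nM, within 9000 nM to 45000 nM, which is a step of a 1.4-fold lower number from compound 2 to compound 3 (0.14 log units; within the scatter).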

Compound 3, half-maximal cytotoxic concentration: 7490 nM
Compound 3: the middle estimate sits 2.7-fold (0.43 log units) above what was measured; measured number below the stated range.
By their numbers in this assay, from the lowest: compounds 3 and 1 (each within the scatter of the next); then compound 2.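

In this assay the aryl ether now shows a change in the other direction: a 3.7-fold lower number from compound 2 to compound 3 (0.57 log units; beyond the scatter), with 2,4,6-tribromophenyl in place of 2,6-dichlorophenyl, which leaves compound 2 with the highest number of the three. The other new comparison, a 1.6-fold lower number from compound 1 to compound 3 (0.22 log units; within the scatter), does not separate 2,4,6-tribromophenyl from 4-bromo-2,6-dimethylphenyl. No measurement at hand accounts for these differences. Open, from the compounds shown here alone, is how an aryl ether carrying an amine or a carboxylic acid, or a longer alkyl chain on the same oxygen, would stand in this assay.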